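Methoxycarbonyl for methylsulfonyl on the side-chain amine

The source may report more compounds than this note shows. Statements on the series, on what has been measured and on what is new or still open speak of the compounds shown alone.

compound 1 `O=C1CCC(=O)N1C[C@H]1CN(c2ccc(-n3cc(-c4ccccn4)cn3)c(F)c2)C(=O)O1` > 400 ug/mL
compound 2 `CS(=O)(=O)NC[C@H]1CN(c2ccc(-n3cc(-c4ccccn4)cn3)c(F)c2)C(=O)O1` > 400 ug/mL

In an ADME assay on L02 cells (Homo sapiens) for cytotoxicity, read by MTT assay, with a stated time of 48 h (on this read-out higher numbers stand for weaker inhibition and lower numbers for stronger inhibition), compound 1 gives > 400 ug/mL, which is a limit of the assay. In this assay compound 2 likewise gives only > 400 ug/mL, again a limit. The step that the two limits leave unreadable from compound 1 to compound 2 is therefore unreadable. Compound 3 `COC(=O)NC[C@H]1CN(c2ccc(-n3cc(-c4ccccn4)cn3)c(F)c2)C(=O)O1` differs from compound 2 by methoxycarbonyl in place of methylsulfonyl on an amine nitrogen. For the measured compounds named here, the only measured step that bears on this change is that unreadable one, and both measured values sit at the same limit (the limit of > 400 ug/mL in this assay, at which 2 of the 2 values shown sit). Compound 3 is thus expected to stay at that limit, so that a number no higher from compound 2 to compound 3 (the limit leaves the size open) is expected to be no change beyond the scatter. Compound 3 is estimated at 400 ug/mL, ranging from 200 ug/mL to 800 ug/mL.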

Compound 3, half-maximal inhibitory concentration: 71 ug/mL
Compound 3: the middle estimate sits 5.6-fold (0.75 log units) above what was measured; the measured number lies below the stated range.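

For the compounds shown here, with methoxycarbonyl in place of methylsulfonyl on the amine nitrogen, this assay records an at least 5.6-fold lower number from compound 2 to compound 3 (0.75 log units; beyond the scatter) in the read-out, so a change at this position can move the value in a way the earlier compounds did not show. Replacing 2,5-dioxopyrrolidin-1-yl with (methoxycarbonyl)amino likewise gives an at least 5.6-fold lower number from compound 1 to compound 3 (0.75 log units; beyond the scatter) on the same read-out, whereas the earlier step between the two limits cannot be read. Compound 3 alone gives a number rather than a limit: the limit of > 400 ug/mL in this assay, at which 2 of the 3 values shown sit.

From the compounds shown here alone, both steps start from a limit, so their full sizes stay open. Also open, going by these compounds, is whether an acetyl or ethoxycarbonyl group on the same amine nitrogen would stay near compound 3 or return to the limit.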